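Trading a Long Ether Chain for Cyclohexyl

This account rests on a few compounds, and the source may have more. Where it says the series, first, only, none or still open, it means among the compounds named here.

Measured so far in an ADME assay on HOS cells (Homo sapiens) for cytotoxicity, read by luminescence and ATP content, with a stated time of 48 h; a higher number here means that more compound is tolerated, a lower number that less compound is tolerated:
compound 1 `COc1ccc2c(N)c(C(=O)NCc3ccc(F)cc3F)c(=O)n(O)c2n1`: 2200 nM
compound 2 `CC(=O)OCCCc1cnc2c(c1)c(N)c(C(=O)NCc1ccc(F)cc1F)c(=O)n2O`: > 250000 nM (a limit of the assay, not a number)
compound 3 `Nc1c(C(=O)NCc2ccc(F)cc2F)c(=O)n(O)c2ncc(CCCCCCOCc3ccccc3)cc12`: 14400 nM

Of the two results that are true numbers, compound 3 holds the higher at 14400 nM, so more of it is tolerated. The other number belongs to compound 1 at 2200 nM, and that gap lies beyond the scatter.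

In compound 4 `Nc1c(C(=O)NCc2ccc(F)cc2F)c(=O)n(O)c2ncc(CCCC3CCCCC3)cc12`, cyclohexyl stands in place of 3-(benzyloxy)propyl on a saturated chain carbon, three bonds along the chain from an aromatic carbon (cyclohexyl in place of 3-(benzyloxy)propyl on a saturated chain carbon, three bonds along the chain from an aromatic carbon). Among the compounds with values here, one measured step bears on this place: an at least 17-fold lower number from compound 2 to compound 3 (1.23 log units; beyond the scatter). That step is large, but it starts from a limit of the assay, and it replaced acetoxy rather than a group with a ring. It shows that the group at this place can move the number in this assay, yet it does not measure the present swap. The group leaving and the group entering each carry a six-membered ring, so compound 4 is expected to stay close to compound 3 at 14400 nM, with no step beyond the scatter in either direction. For compound 4 the estimated value is 12000 nM, with an expected range from 4000 nM to 40000 nM. This estimate means a 1.2-fold lower number from compound 3 to compound 4 (0.08 log units; within the scatter).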

Compound 4, half-maximal cytotoxic concentration: 27400 nM
Compound 4: middle estimate off by 2.3-fold (0.36 log units), on the low side; the range from low to high includes it.
By their numbers in this assay, from the lowest: compound 1; then compounds 3 and 4 (each within the scatter of the next). At a limit, above all of these: compound 2.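

In this assay, the swap of 3-(benzyloxy)propyl for cyclohexyl gives a 1.9-fold higher number from compound 3 to compound 4 (0.28 log units; within the scatter), so compound 3 and compound 4 cannot be told apart in this read-out. Within the data shown here, this is the first direct comparison of two ring-bearing groups at this place, on a saturated chain carbon, three bonds along the chain from an aromatic carbon: the entering group has fewer heavy atoms, no oxygen and a non-aromatic ring, and none of these differences produces a step beyond the scatter. The comparison with the acetoxy compound, an at least 9.1-fold lower number from compound 2 to compound 4 (0.96 log units; beyond the scatter), shows that a second ring-bearing group also falls clearly short of compound 2, whose result is a limit of the assay and not a number: the limit of > 250000 nM in this assay, at which 1 of the 4 values shown sits.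

From the compounds shown here alone, what remains open is whether the ring itself matters here or whether any large carbon-rich group on this chain would give a similar result. A plain longer chain with no ring, or an amine or a carboxylic acid at the end of the same chain, would help separate these possibilities.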